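The source may hold more compounds than are shown below. What is called first, only, known or untested is meant among the compounds shown, and "the series" means these compounds.

Compound 1 `Cc1cc(NC(=O)Nc2ccccc2F)c2ccccc2n1` gives > 25000 nM in an ADME assay on HepG2 cells (Homo sapiens) for cytotoxicity, with a stated time of 72 h (a higher number here means that more compound is needed for the effect, a lower number that less compound is needed), a limit rather than a number. Compound 2 `Cc1cc(NC(=O)Nc2cccc(Cl)c2)c2ccccc2n1` gives 19000 nM. Compound 3 `Cc1cc(NC(=O)Nc2ccc(F)cc2)c2ccccc2n1` gives > 25000 nM, again only a limit.

Compound 3 thus stands at the limit of > 25000 nM in this assay, at which 2 of the 3 values shown sit. Compound 2 alone yields a number, and that number lies close to the limit. Compound 4 `Cc1cc(NC(=O)Nc2ccc(F)cc2F)c2ccccc2n1` differs from compound 3 by fluoro in place of hydrogen on an aromatic carbon. Among the compounds with values here, the steps that bear on this are a step that the two limits leave unreadable from compound 1 to compound 3, an at least 1.3-fold higher number from compound 2 to compound 3 (0.11 log units; that floor lies within the scatter) and an at least 1.3-fold lower number from compound 1 to compound 2 (0.11 log units; that floor lies within the scatter); moving the halogen around the phenyl never gave a readable step beyond the scatter. The added fluoro is therefore expected to leave compound 4 at or near the limit in this assay, with a number no higher from compound 3 to compound 4 (the limit leaves the size open) expected to stay within the scatter. Compound 4 is estimated at 25000 nM, within 10000 nM to 60000 nM.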

Compound 4, half-maximal effective concentration: 17000 nM
Estimate against measurement, compound 4: 1.5-fold (0.17 log units) above; the measured number falls inside the stated range.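

In this assay, fluoro in place of hydrogen on an aromatic carbon, ortho to a large group, gives an at least 1.4-fold lower number from compound 3 to compound 4 (0.16 log units; that floor lies within the scatter), and the comparison from the other monofluoro compound gives an at least 1.4-fold lower number from compound 1 to compound 4 (0.16 log units; that floor lies within the scatter). Compound 4 thus yields a number where compound 3 and compound 1 yield only limits, yet neither printed floor lies beyond the scatter. The true size of both steps stays open, because each starts from a limit: the limit of > 25000 nM in this assay, at which 2 of the 4 values shown sit.

The compounds shown leave open whether a methoxy group or an amine in place of this fluoro would give a step beyond the scatter. They also leave open whether a chloro group here would behave as the fluoro does.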